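Lengthening the chain on the ring nitrogen of compound 3

This account rests on a few compounds, and the source may have more. Where it says the series, first, only, none or still open, it means among the compounds named here.

Compound 3 `CCCc1c(OCCCCOc2ccc(-c3nn[nH]n3)cc2)ccc2c1ccn2CCC` sits among three close neighbours. In a functional assay for binding affinity to metabotropic glutamate receptor 2 (Homo sapiens), read by GTPgammaS binding, with a stated time of 1 h, at 30 degrees C (on this read-out higher numbers stand for an effect only at larger amounts of compound and lower numbers for an effect already at smaller amounts), compound 3 gives 652 nM; compound 1 `CCCc1c(OCCCCOc2ccc(-c3nn[nH]n3)cc2)ccc2c1ccn2CC(C)(C)C` gives 559 nM, and compound 2 `CCCc1c(OCCCCOc2ccc(-c3nn[nH]n3)cc2)ccc2c1CCN2CC(C)(C)C`, whose core is partly saturated, gives 1170 nM. All three numbers lie within the usual scatter of one another, so none can be called stronger. Compound 4 `CCCCCn1ccc2c(CCC)c(OCCCCOc3ccc(-c4nn[nH]n4)cc3)ccc21` carries ethyl in place of hydrogen on a saturated chain carbon, three bonds along the chain from an aromatic nitrogen. For the measured compounds named here, the only comparable step measured, a 1.2-fold higher number from compound 1 to compound 3 (0.07 log units; within the scatter), changed the same chain and stayed within the scatter, so the further lengthening here is expected to bring no step beyond the scatter in this assay. Compound 4 is therefore estimated at 650 nM, with a likely range from 300 nM to 1400 nM, which means an expected step of a 1.0-fold lower number from compound 3 to compound 4 (0.00 log units; within the scatter).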

Compound 4, half-maximal effective concentration: 598 nM
Beside the measured number, compound 4's estimate is 1.1-fold (0.04 log units) above it; the measured number falls inside the stated range.
By their numbers in this assay, from the lowest: compounds 1, 4, 3 and 2 (each within the scatter of the next, the first and the last beyond it).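

In this assay, going from propyl to pentyl on the aromatic nitrogen gives a 1.1-fold lower number from compound 3 to compound 4 (0.04 log units; within the scatter) and so adds a longer straight chain to what this position holds without a readable change. Butyl in place of tert-butyl gives a 1.1-fold higher number from compound 1 to compound 4 (0.03 log units; within the scatter), so the straight and branched chains also read alike here. Nothing available explains why these chains read alike. Still open, on these data alone, is whether an amine, a carboxylic acid or a phenyl ring on this chain, or a chain longer than pentyl, would move the number beyond the scatter.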